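The compounds below may be only part of what the source reports. "The series", "measured", "known", "first", "only" and "open" are said of these compounds alone.

The measured compounds are compound 1, `CCCCCCCCN[C@@H]1C=C[C@H](O)[C@H](O)[C@H]1O`, with 120000 nM in an assay for inhibition of beta-galactosidase (Homo sapiens), read by fluorescence, with a stated time of 30 min, at pH 4.5 (a higher number here means a weaker inhibitor, a lower number a stronger inhibitor), and compound 2, `CCCCCN[C@@H]1C=C[C@H](O)[C@H](O)[C@H]1O`, which gives 19000 nM in this assay.

Among the compounds with values here, compound 2 holds the lowest number of the two; its only neighbour is compound 1, which sits a clear step higher: a 6.3-fold lower number from compound 1 to compound 2 (0.80 log units; beyond the scatter). Within the data shown here, that step is the sole measured change in this set, and it concerns the length of the chain on the amine nitrogen of the shared core.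

Compound 3, `OCCCN[C@@H]1C=C[C@H](O)[C@H](O)[C@H]1O`, is not yet measured. It differs from compound 2 in one place: hydroxy in place of ethyl on a saturated chain carbon, three bonds along the chain from an amine nitrogen. Among the measured compounds shown here, this change again shortens the chain, as the step from compound 1 to compound 2 did, but it also brings in a hydroxy, for which no measured step exists. Only the chain-shortening step can guide the expectation, and the hydroxy adds uncertainty in both directions. On that basis compound 3 is expected to come out somewhat lower than compound 2, a 2.4-fold lower number from compound 2 to compound 3 (0.38 log units; beyond the scatter), and its value in this assay is estimated at 8000 nM, within a range from 2000 nM to 40000 nM.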

Compound 3, half-maximal inhibitory concentration: > 1000000 nM
Compound 3: no number, only a limit; the forecaster's own chance of this, stated with the estimate: 5%; middle value at least 120-fold (2.09 log units) away from the limit.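

Compound 3 reads > 1000000 nM in this assay, and this is a limit of the assay, not a number: the limit of > 1000000 nM in this assay, at which 1 of the 3 values shown sits.

The earlier pair showed only that a shorter chain on the amine nitrogen went with a lower number, whereas hydroxy in place of ethyl, three bonds along the chain from an amine nitrogen, turns the direction round and gives an at least 52-fold higher number from compound 2 to compound 3 (1.72 log units; beyond the scatter) as a large step. The reading also passes that of the chain in compound 1, with an at least 8.3-fold higher number from compound 1 to compound 3 (0.92 log units; beyond the scatter), so compound 3 goes against the trend from the first pair, and chain length alone does not order these three compounds.

The compounds shown leave open how much of the rise belongs to the hydroxy and how much to the shortening itself, a question that a plain propyl chain on the amine nitrogen would help to separate. They also leave open whether a methoxy or an amine at the same place would read like the hydroxy, and whether a hydroxy on a longer chain would give a reading within the range of the assay.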